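Swapping a propyl chain for a pyridinylmethyl group

The source may hold more compounds than are shown below. What is called first, only, known or untested is meant among the compounds shown, and "the series" means these compounds.

This small set shares one core. Compound 1 `Nc1nc(Cl)c(-c2ccccn2)c(N[C@@H]2C[C@H](CO)[C@@H](O)[C@H]2O)n1` gives in an ADME assay on cells (Homo sapiens) for cytotoxicity, read by polymerase chain reaction, with a stated time of 3 days (on this read-out lower numbers stand for higher toxicity in this test and higher numbers for lower toxicity in this test), only a limit, > 25000 nM. Compound 2 `CCCNc1nc(C)c(-c2nc3ccccc3s2)c(N[C@@H]2C[C@H](CO)[C@@H](O)[C@H]2O)n1` carries a propylamino group, and in this assay compound 2 likewise gives only a limit, > 25000 nM. Compound 3 `COCCNc1nc(C)c(-c2nc3ccccc3s2)c(N[C@@H]2C[C@H](CO)[C@@H](O)[C@H]2O)n1` gives in this assay a number, 21000 nM. Among the measured compounds shown here, the one measured step, an at least 1.1-fold lower number from compound 2 to compound 3 (0.07 log units; that floor lies within the scatter), stays within the scatter, so the three compounds cannot be told apart on these numbers; two of them sit at the limit of > 25000 nM in this assay, at which 2 of the 3 values shown sit.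

Compound 4 `Cc1nc(NCc2ccncc2)nc(N[C@@H]2C[C@H](CO)[C@@H](O)[C@H]2O)c1-c1nc2ccccc2s1` differs from compound 2 by pyridin-4-yl in place of ethyl on a saturated chain carbon bound to a nitrogen on an aromatic ring. For the measured compounds named here, no measured step puts an aromatic ring in that place; the only step on record, an at least 1.1-fold lower number from compound 2 to compound 3 (0.07 log units; that floor lies within the scatter), altered the chain itself and stayed within the scatter. The expectation for compound 4 in this assay is therefore no step beyond the scatter, that is a number no higher from compound 2 to compound 4 (the limit leaves the size open). The estimate for compound 4 is 25000 nM, expected to fall between 12000 nM and 50000 nM, and a limit rather than a number for compound 4 is quite possible.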

Compound 4, half-maximal cytotoxic concentration: 7000 nM
Compound 4: the middle estimate sits 3.6-fold (0.55 log units) above what was measured, outside the stated range (below it).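

Unlike the change within the chain itself, this change at the same place moves the number beyond the scatter in this assay: the swap to pyridin-4-yl gives an at least 3.5-fold lower number from compound 2 to compound 4 (0.55 log units; beyond the scatter), and the swap from the methoxy-bearing chain gives a 3.0-fold lower number from compound 3 to compound 4 (0.48 log units; beyond the scatter). What stands on this saturated chain carbon therefore matters, and with an aromatic ring there, the read-out points to higher toxicity in this test. The first of these steps is only a floor, its full size left open: the limit of > 25000 nM in this assay, at which 2 of the 4 values shown sit.

With only one aromatic group at this place, the compounds shown leave open whether the ring nitrogen matters, and a plain phenyl group would test that. They also leave open whether a longer chain carrying the same pyridin-4-yl ring would give a similar number.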